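A few compounds are considered here, and "the series" means these few. Any claim that something is new, unique, unknown or untested is made for them only; others in the source may bear on it.

Measured so far:
- compound 1, `CC[C@@H]1/C=C(\C)C[C@H](C)C[C@H](OC)[C@H]2O[C@@](O)(C(=O)C(=O)N3CCCC[C@H]3C(=O)O[C@H](/C(C)=C/[C@@H]3CC[C@@H](O)[C@H](Oc4ccc(O)cc4)C3)[C@H](C)[C@@H](O)CC1=O)[C@H](C)C[C@@H]2OC`: 0.9 nM
- compound 2, `CC[C@@H]1/C=C(\C)C[C@H](C)C[C@H](OC)[C@H]2O[C@@](O)(C(=O)C(=O)N3CCCC[C@H]3C(=O)O[C@H](/C(C)=C/[C@@H]3CC[C@@H](Oc4ccc(F)cc4)[C@H](OC)C3)[C@H](C)[C@@H](O)CC1=O)[C@H](C)C[C@@H]2OC`: 3.4 nM
- compound 3, `CC[C@@H]1/C=C(\C)C[C@H](C)C[C@H](OC)[C@H]2O[C@@](O)(C(=O)C(=O)N3CCCC[C@H]3C(=O)O[C@H](/C(C)=C/[C@@H]3CC[C@@H](Oc4cc(C(F)(F)F)cc(C(F)(F)F)c4)[C@H](OC)C3)[C@H](C)[C@@H](O)CC1=O)[C@H](C)C[C@@H]2OC`: 607 nM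

In a functional assay on cells for inhibition, with Murine T-cell line (Mus musculus) as the target (a lower number here means a stronger inhibitor, a higher number a weaker inhibitor), compound 1 gives 0.9 nM, compound 2 gives 3.4 nM and compound 3 gives 607 nM. Compound 2 holds the second highest number of the three; its nearest neighbour is compound 1, with a lower number beyond the scatter, and compound 3 lies far above it, also well beyond the scatter. Among the compounds with values here, no single-point step between the measured compounds is available.

Compound 4, `CC[C@@H]1/C=C(\C)C[C@H](C)C[C@H](OC)[C@H]2O[C@@](O)(C(=O)C(=O)N3CCCC[C@H]3C(=O)O[C@H](/C(C)=C/[C@@H]3CC[C@@H](Oc4ccc(SC)cc4)[C@H](OC)C3)[C@H](C)[C@@H](O)CC1=O)[C@H](C)C[C@@H]2OC`, has not been measured. It differs from compound 2 in one place: methylsulfanyl in place of fluoro on an aromatic carbon. Methylsulfanyl brings two heavy atoms and one hydrogen-bond acceptor where fluoro brought one heavy atom and none. On the shared core, compound 3 shows that a heavier substitution pattern on the phenoxy ring can cost a great deal, while compound 1 and compound 2 show that small single groups keep the number low. A modest rise is expected from compound 2 to compound 4, a 2.4-fold higher number from compound 2 to compound 4 (0.37 log units; beyond the scatter), likely beyond the scatter but nowhere near compound 3. For compound 4 the expected value in this assay is 8 nM, within 2.5 nM to 30 nM.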

Compound 4, half-maximal inhibitory concentration: 2.6 nM
Estimate against measurement, compound 4: 3.1-fold (0.49 log units) above; the range from low to high includes it.
By their numbers in this assay, from the lowest: compound 1; then compounds 4 and 2 (each within the scatter of the next); then compound 3.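

Within the data shown here, the step of a 1.3-fold lower number from compound 2 to compound 4 (0.12 log units; within the scatter) in this assay is the first single-place comparison, and it concerns the aromatic carbon para to a large group. At this position, methylsulfanyl, with its two heavy atoms and one hydrogen-bond acceptor, cannot be told apart from fluoro, with its one heavy atom and no acceptor. No measurement shown here accounts for this result.

The series leaves open whether a group of a different kind on the same aromatic carbon, such as an amine or a carboxylic acid, would also stay within the scatter of compound 2. It also leaves open whether methylsulfonyl or a longer chain on the sulfur, such as ethylsulfanyl, would do the same.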